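The source may hold more compounds than are shown below. What is called first, only, known or untested is meant among the compounds shown, and "the series" means these compounds.

Of the compounds shown here, three have so far been tested in a functional assay on the whole organism (Tail, strain ICR) with Mus musculus as the target, in the tail flick test, with a stated time of 90 min, at a dose of 25 umol/kg by the oral route; on this read-out higher numbers stand for a stronger effect at the one dose given and lower numbers for a weaker effect. Compound 1 `O=C(O)[C@@H]1CCCN1C(=O)CN(c1nc(Cl)nc2[nH]cnc12)C1CC1` gives 26%, compound 2 `N=C(N)NCCC[C@H](NC(=O)CN(c1nc(Cl)nc2[nH]cnc12)C1CC1)C(=O)O` gives 27.6%, and compound 3 `O=C(CN(c1ncnc2c1ncn2C1CCCCO1)C1CC1)N[C@@H](CCC(=O)OCc1ccccc1)C(=O)OCc1ccccc1` gives 25.2%. Compound 2 holds the highest of these three numbers, yet compound 1 and compound 3 both lie within the usual scatter of it, so no order can be drawn. Compound 4 `CC[C@H](C)[C@H](NC(=O)CN(c1nc(Cl)nc2[nH]cnc12)C1CC1)C(=O)O` awaits measurement in this assay. It differs from compound 2 in one place: a group of 4 heavy atoms (4 carbon; no ring) in place of a group of 7 heavy atoms (4 carbon, 3 nitrogen; no ring), on a saturated chain carbon bound to an amide-type nitrogen and a carbonyl carbon. For the measured compounds named here, no step between measured compounds shows how such an exchange moves this read-out, and the measured numbers cluster closely. The expected step of a number 1.6 percentage points lower from compound 2 to compound 4 (within the scatter) is therefore small, with no direction beyond the scatter. Compound 4 is estimated at 26%, in a range from 14% to 38%.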

Compound 4, a percentage reported as activity, at one dose (the size of the read-out at that dose, not a potency): 27.4%
For compound 4 the middle estimate is 1.4 percentage points below the measured one, within the range that was stated.
By their numbers in this assay, from the lowest: compounds 3, 1, 4 and 2 (each within the scatter of the next).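

For the compounds shown here, the first exchange that can be read at this place gives a number 0.2 percentage points lower from compound 2 to compound 4 (within the scatter) in this assay. On this read-out, at this one dose, the group of 7 heavy atoms with its nitrogens and the all-carbon sec-butyl group therefore cannot be told apart on a saturated chain carbon bound to an amide-type nitrogen and a carbonyl carbon. No supporting measurement bears on this result. On these data alone, whether a hydroxymethyl group or a longer straight carbon chain at this place would give a step beyond the scatter stays open.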